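Aryl variation on the shared core: antiproliferative working notes

The compounds below may be only part of what the source reports. "The series", "measured", "known", "first", "only" and "open" are said of these compounds alone.

compound 1 `COc1cc(-n2cnc3ccc(-c4cccc(F)c4)cc32)cc(OC)c1OC` — 2490 nM
compound 2 `COc1cc(-n2cnc3ccc(-c4cccc(C)c4C)cc32)cc(OC)c1OC` — 3040 nM
compound 3 `COc1cc(-n2cnc3ccc(-c4ccccc4Cl)cc32)cc(OC)c1OC` — > 10000 nM, a limit of the assay, not a number

All values come from a functional assay on SGC-7901 cells (Homo sapiens) for antiproliferative activity, read by MTT assay, with a stated time of 72 h; on this read-out higher numbers stand for weaker inhibition and lower numbers for stronger inhibition. Among the two numbers given, compound 2 stands at the higher one, with compound 1 nearest: the step of a 1.2-fold higher number from compound 1 to compound 2 (0.09 log units; within the scatter). Compound 3 sits at the assay limit (the limit of > 10000 nM in this assay, at which 1 of the 3 values shown sits). Compound 4 `COc1cc(-n2cnc3ccc(-c4ccc(C)cc4F)cc32)cc(OC)c1OC` remains to be measured. The change from compound 2 is 2-fluoro-4-methylphenyl in place of 2,3-dimethylphenyl on an aromatic carbon. For the measured compounds named here, two measured steps bear on it. The step of an at least 3.2-fold higher number from compound 2 to compound 3 (0.51 log units; beyond the scatter) shows that a 2-chlorophenyl moved the number out to the limit, while the step of a 1.2-fold higher number from compound 1 to compound 2 (0.09 log units; within the scatter) shows that exchanging 3-fluorophenyl and 2,3-dimethylphenyl changed little. The incoming 2-fluoro-4-methylphenyl carries fluorine, as did compound 1, and a methyl, as did compound 2. The step of a 1.3-fold higher number from compound 2 to compound 4 (0.12 log units; within the scatter) is therefore expected to be small, at most modest, and toward a higher number. For compound 4 the estimate is 4000 nM, with a range from 1500 nM to 12000 nM, and a real chance that only a limit is reported.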

Compound 4, half-maximal inhibitory concentration: 5650 nM
Estimate against measurement, compound 4: 1.4-fold (0.15 log units) below; the measured number falls inside the stated range.
By their numbers in this assay, from the lowest: compounds 1, 2 and 4 (each within the scatter of the next, the first and the last beyond it). At a limit, above all of these: compound 3.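

In this assay, 2-fluoro-4-methylphenyl in place of 2,3-dimethylphenyl gives a 1.9-fold higher number from compound 2 to compound 4 (0.27 log units; within the scatter), so a second methyl-bearing aryl group stays on scale at this position. Against 3-fluorophenyl the same group gives a 2.3-fold higher number from compound 1 to compound 4 (0.36 log units; beyond the scatter), the first step beyond the scatter at this position with a true number at both ends, and it separates two fluorine-bearing aryl groups. Going by these compounds, compound 3 stays at a limit of the assay, not a number: the limit of > 10000 nM in this assay, at which 1 of the 4 values shown sits. Measured from that limit, 2-fluoro-4-methylphenyl in place of 2-chlorophenyl gives an at least 1.7-fold lower number from compound 3 to compound 4 (0.24 log units; that floor lies within the scatter), so this step is known only as a floor and its full size stays open.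

Fluorine and methyl enter together in compound 4, so how 2-fluorophenyl or 4-methylphenyl would each read alone stays open. Also open, on these data alone, is whether an aryl group bearing an amine or a carboxylic acid would hold a number at this position.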